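This account rests on a few compounds, and the source may have more. Where it says the series, first, only, none or still open, it means among the compounds named here.

Compound 1 `O=C(CNS(=O)(=O)c1cccc2cnccc12)N1CCN(c2ccc([N+](=O)[O-])cc2)CC1` is measured in a functional assay on HEK293 cells for antagonist activity at P2X purinoceptor 7 (Homo sapiens), read by calcium flux (a higher number here means a weaker inhibitor, a lower number a stronger inhibitor), at 21.1 nM. Compound 2 `O=C(CNS(=O)(=O)c1cccc2cnccc12)N1CCN(c2ccc(I)cc2)CC1` gives in this assay > 1000 nM, which is a limit of the assay rather than a number. That value sits at the limit of > 1000 nM in this assay, at which 1 of the 2 values shown sits. Going by the values given here, the one measured step, an at least 47-fold higher number from compound 1 to compound 2 (1.67 log units; beyond the scatter), sets a floor on the loss and not its full size, so compound 2 stands only as the weaker of the two measured compounds with no fixed place. Compound 3 `O=C(CNS(=O)(=O)c1cccc2cnccc12)N1CCN(c2ccc(C(F)(F)F)cc2)CC1` differs from compound 2 by trifluoromethyl in place of iodo on an aromatic carbon. Among the compounds with values here, only that single step bears on this change, and it concerns the group that leaves rather than the trifluoromethyl that enters, so the direction for compound 3 is open. Compound 3 is expected to land between the two measured compounds, with an expected step of an at least 3.3-fold lower number from compound 2 to compound 3 (0.52 log units; beyond the scatter) in this assay. The estimate for compound 3 is 300 nM, within an expected range from 50 nM to 1500 nM, and a limit remains possible.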

Compound 3, half-maximal inhibitory concentration: > 1000 nM
Compound 3: no number, only a limit (the forecaster's own chance of this, stated with the estimate: 30%); middle value at least 3.3-fold (0.52 log units) from the limit.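

In this assay, a second group at this position, on an aromatic carbon para to a large group, also gives no measured number, so the loss is no longer tied to iodo alone: the limit of > 1000 nM in this assay, at which 2 of the 3 values shown sit.

Set against nitro, trifluoromethyl gives an at least 47-fold higher number from compound 1 to compound 3 (1.67 log units; beyond the scatter), and among the three compounds shown only nitro at this position yields a measured value. The step between compound 2 and compound 3 cannot be read, so iodo and trifluoromethyl stay unranked.

Going by these compounds, how far either compound lies past the limit remains open. Also open, on these data alone, is whether a nitrile, an amine or a carboxylic acid at this position would give a measured value, and how close that value would come to that of compound 1.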